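This account rests on a few compounds, and the source may have more. Where it says the series, first, only, none or still open, it means among the compounds named here.

Measured so far:
Compound 1, `O=C(O)c1csc([C@H]2CC[C@@H]3[C@@H](/C=C/CCCOc4ccccc4)[C@H](O)C[C@@H]3O2)n1`, with 13 nM in a functional assay on CHO cells for agonist activity at prostaglandin E2 receptor EP2 subtype (Homo sapiens), read by HTRF and cAMP accumulation, with a stated time of 30 min; on this read-out higher numbers stand for an effect only at larger amounts of compound and lower numbers for an effect already at smaller amounts.
Compound 2, `O=C(O)c1csc([C@H]2CC[C@@H]3[C@@H](COc4ccccc4F)[C@H](O)C[C@@H]3O2)n1`, with 23 nM in this assay.

Of the two numbers on hand, compound 2 carries the higher one; the nearest is compound 1, whose number is lower by a gap that lies within the scatter, so the two values show no separation that can be read as an order.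

Compound 3, `O=C(O)c1csc([C@H]2CC[C@@H]3[C@@H](COc4cccc(F)c4)[C@H](O)C[C@@H]3O2)n1`, is not yet measured. It differs from compound 2 in one place: 3-fluorophenyl in place of 2-fluorophenyl on an oxygen on a saturated carbon.

No pair of measured compounds shows what this change does, so the expected step is an estimate with no shown precedent. The expectation is that the step from compound 2 to compound 3 in this assay is a 1.1-fold higher number from compound 2 to compound 3 (0.04 log units; within the scatter), that is, no change beyond the scatter in either direction. On that basis compound 3 is expected to give about 25 nM in this assay, with an estimated range from 8 nM to 80 nM.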

Compound 3, half-maximal effective concentration: 5.4 nM
For compound 3 the middle estimate is 4.6-fold (0.67 log units) above the measured one; measured number below the stated range.
By their numbers in this assay, from the lowest: compound 3; then compounds 1 and 2 (each within the scatter of the next).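

Among the compounds shown here, the exchange of 2-fluorophenyl for 3-fluorophenyl on an oxygen on a saturated carbon gives a 4.3-fold lower number from compound 2 to compound 3 (0.63 log units; beyond the scatter) in this assay and is the first single-place change that can be read. For the compounds shown here, the two groups hold the same heavy atoms, joined differently, and that difference alone is enough here to move the number beyond the scatter, which the earlier compounds could not show. Nothing at hand explains why this place responds to the exchange.

The compounds shown leave open how 4-fluorophenyl, unsubstituted phenyl or 3-chlorophenyl would behave at this place. They also leave open whether the same exchange would give a similar step on the longer alkene chain of compound 1, whose phenyl ring carries no fluorine.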